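From ethyl(methyl)amino to azetidin-1-yl on the carbonyl

The source may report more compounds than this note shows. Statements on the series, on what has been measured and on what is new or still open speak of the compounds shown alone.

In an ADME assay on MDCKII-LE cells (Canis lupus familiaris) for permeability (on this read-out lower numbers stand for lower permeability and higher numbers for higher permeability), compound 3 (`CCN(C)C(=O)c1cnc(Oc2cc(C(=O)Nc3cnc(C)cn3)cc3oc(C)cc23)cn1`) gives 24.1 10^-6 cm/s and stands highest of the three measured compounds, with compound 2 (`Cc1cnc(NC(=O)c2cc(Oc3ccc(C#N)cc3)c3cc(C)oc3c2)cn1`) at 1.5 10^-6 cm/s and compound 1 (`Cc1ccc(Oc2cc(C(=O)Nc3cnc(C)cn3)cc3oc(C)cc23)cc1`) at 0.3 10^-6 cm/s lower down. Compound 4 (`Cc1cnc(NC(=O)c2cc(Oc3cnc(C(=O)N4CCC4)cn3)c3cc(C)oc3c2)cn1`) differs from compound 3 in one place: azetidin-1-yl in place of ethyl(methyl)amino on a carbonyl carbon. Going by the values given here, the only measured single-place step (a 5.0-fold higher number from compound 1 to compound 2 (0.70 log units; beyond the scatter)) was modest, and it swaps methyl for cyano on an aromatic carbon, leaving this carbonyl untouched. Nothing measured tests the present change directly. A small decrease, not beyond the scatter, is therefore expected in this assay (a 1.3-fold lower number from compound 3 to compound 4 (0.13 log units; within the scatter)). Compound 4 is estimated at 18 10^-6 cm/s (range 7 10^-6 cm/s to 35 10^-6 cm/s).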

Compound 4, apparent permeability: 17.4 10^-6 cm/s
Estimate against measurement, compound 4: 1.0-fold (0.01 log units) above; the range from low to high includes it.
By their numbers in this assay, from the lowest: compound 1; then compound 2; then compounds 4 and 3 (each within the scatter of the next).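

In this assay, azetidin-1-yl in place of ethyl(methyl)amino on the carbonyl carbon gives a 1.4-fold lower number from compound 3 to compound 4 (0.14 log units; within the scatter), so at this position a four-membered ring can stand for the open chain of equal heavy-atom count with no change beyond the scatter. This is the only step shown at this carbonyl, as the earlier step concerned an aromatic carbon. No evidence is available to explain the result.

On these data alone, it remains open how this read-out responds to a morpholin-4-yl or piperidin-1-yl group on the same carbonyl, or to a carboxylic acid there.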